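Trimming the hydroxycarbamoyl chain further

The source may hold more compounds than are shown below. What is called first, only, known or untested is meant among the compounds shown, and "the series" means these compounds.

Compound 1 `CC(C)c1cc(-c2n[nH]c(=O)n2-c2ccc(C(=O)NCCCCCCCC(=O)NO)cc2)c(O)cc1O`: 4600 nM
Compound 2 `CC(C)c1cc(-c2n[nH]c(=O)n2-c2ccc(C(=O)NCCCCC(=O)NO)cc2)c(O)cc1O`: 4600 nM

In a functional assay on A549 cells (Homo sapiens) for inhibition (on this read-out higher numbers stand for weaker inhibition and lower numbers for stronger inhibition), compound 2 gives 4600 nM, level with compound 1 at 4600 nM. The unmeasured compound 3 `CC(C)c1cc(-c2n[nH]c(=O)n2-c2ccc(C(=O)NCCCC(=O)NO)cc2)c(O)cc1O` has a shorter chain leading to the hydroxycarbamoyl end: hydroxycarbamoyl in place of (hydroxycarbamoyl)methyl on a saturated chain carbon, three bonds along the chain from an amide-type nitrogen. Hydroxycarbamoyl takes the place of (hydroxycarbamoyl)methyl on a saturated chain carbon, three bonds along the chain from an amide-type nitrogen. Going by the values given here, one measured step bears on this, a similar trimming of the same chain: no change at the digits printed from compound 1 to compound 2 (within the scatter). That step did not go beyond the scatter, so no step beyond the scatter is expected in this assay here. Still, a single step cannot show whether this holds for a shorter chain, which is why the range is wide. The expected step is a 1.1-fold higher number from compound 2 to compound 3 (0.04 log units; within the scatter). For compound 3 the estimated value is 5000 nM, with an expected range of 2400 nM to 11000 nM.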

Compound 3, half-maximal inhibitory concentration: 4600 nM
Estimate against measurement, compound 3: 1.1-fold (0.04 log units) above; the range from low to high includes it.
By their numbers in this assay, from the lowest: compounds 1, 2 and 3 (each within the scatter of the next).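

In this assay the further trimming gives no change at the digits printed from compound 2 to compound 3 (within the scatter) and so the flat result of the first trimming extends to a shorter chain. Across the full span there is no change at the digits printed from compound 1 to compound 3 (within the scatter) so these three chain lengths cannot be told apart on this read-out. No measured evidence is available to say why the value holds steady.

On these data alone, all three compounds carry the hydroxycarbamoyl end, so it remains open whether the flat result would survive replacing that group with a carboxylic acid or a primary amide. Also open, as far as these compounds go, is whether a chain shorter than in compound 3, or longer than in compound 1, would move the number beyond the scatter.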